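The source may report more compounds than this note shows. Statements on the series, on what has been measured and on what is new or still open speak of the compounds shown alone.

Measured compounds:
- compound 1, `COCc1ccc(Nc2nnc(Cc3c(Cl)cccc3Cl)o2)cc1`: 100000 nM
- compound 2, `[O-][n+]1ccc(OCc2ccc(Nc3ncc(Cc4c(F)cccc4F)o3)cc2Cl)cc1`: 1700 nM
- compound 3, `N#Cc1ccc(Nc2ncc(Cc3c(F)cccc3F)o2)cc1`: 7400 nM

In an ADME assay on MT2 cells (Homo sapiens) for cytotoxicity, read by MTT assay (a higher number here means that more compound is tolerated, a lower number that less compound is tolerated), compound 1 gives 100000 nM, the highest of the three numbers. Compound 3 gives 7400 nM, and compound 2 gives 1700 nM; both gaps to compound 1 lie beyond the usual scatter, so compound 1 is the best tolerated of the three. No two of these compounds differ in one place only, so no single structural step can be read from the measured set.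

Compound 4, `Clc1cccc(Cl)c1Cc1nnc(Nc2ccc(COCc3ccccc3)cc2)o1`, is built from compound 1 by one change: phenyl in place of hydrogen on a saturated chain carbon bound to an oxygen on a saturated carbon. The methoxymethyl of compound 1 thus becomes a (benzyloxy)methyl. Within the data shown here, with no measured pair to guide the size of this step, the expectation rests on the tendency of larger, more heavily substituted compounds in this set to give lower numbers. Compound 4 is therefore expected to be somewhat less well tolerated than compound 1, with an expected step of a 2.5-fold lower number from compound 1 to compound 4 (0.40 log units; beyond the scatter) in this assay. The estimated value for compound 4 is 40000 nM, with a range from 10000 nM to 100000 nM.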

Compound 4, half-maximal cytotoxic concentration: 84000 nM
The estimate for compound 4 lay 2.1-fold (0.32 log units) below the measured number; the range from low to high includes it.
By their numbers in this assay, from the lowest: compound 2; then compound 3; then compounds 4 and 1 (each within the scatter of the next).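

In this assay, among these compounds, the step from methoxymethyl to (benzyloxy)methyl gives a 1.2-fold lower number from compound 1 to compound 4 (0.08 log units; within the scatter), the first one-place comparison in this set. At this position, then, phenyl in place of hydrogen on a saturated chain carbon bound to an oxygen on a saturated carbon yields a compound that cannot be told apart from its parent in this assay, so a group of this size is tolerated here without a separable shift in the number. Nothing at hand accounts for this result.

As far as these compounds go, whether other groups at this place, such as an amine, a carboxylic acid or a longer chain, would behave in the same way remains open. So does whether a phenyl bearing a chlorine or a nitrile would match the plain phenyl, since this single step speaks only for the unsubstituted ring on this core.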